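Sulfonamide series: aryl replacement and metabolic stability

A few compounds are considered here, and "the series" means these few. Any claim that something is new, unique, unknown or untested is made for them only; others in the source may bear on it.

Compound 1 `Cc1cc(Cl)cc(Cl)c1S(=O)(=O)N1CCC(N2CCC(C)CC2)CC1`, compound 2 `COc1ccccc1-c1ccc(S(=O)(=O)N2CCC(N3CCC(C)CC3)CC2)cc1` and compound 3 `CC1CCN(C2CCN(S(=O)(=O)c3cccc(-c4ccc5ccccc5c4)c3)CC2)CC1` share a common core and differ only in the aromatic part. In an ADME assay on S9 fraction from liver (Mus musculus, strain ICR/CD-1) for metabolic stability, read by LC-MS, using NADPH, with a stated time of 5 min, tested at 2 uM (on this read-out higher numbers stand for a longer-lived compound and lower numbers for a shorter-lived compound), compound 1 gives 0.12 h. In this assay compound 2 gives 4.82 h. In this assay compound 3 gives 3.4 h, the second highest of the three numbers; the value of compound 3 and that of compound 2 lie within the scatter of each other, whereas compound 1 stands far lower, well beyond the scatter. Compound 4 `Cc1ccc(-c2cccc(S(=O)(=O)N3CCC(N4CCC(C)CC4)CC3)c2)cc1` has not yet been measured. It differs from compound 3 by 4-methylphenyl in place of naphthalen-2-yl on an aromatic carbon. Among the measured compounds shown here, no step between measured compounds speaks directly to this change; compound 2 and compound 3 both give long half-lives, and compound 4 resembles them more closely than it resembles compound 1. The expected step is a 1.7-fold lower number from compound 3 to compound 4 (0.23 log units; within the scatter), leaning toward a somewhat shorter half-life but not beyond the scatter. Compound 4 is expected to give 2 h in this assay, with a range from 0.7 h to 5.5 h.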

Compound 4, half-life: 1.92 h
For compound 4 the middle estimate is 1.0-fold (0.02 log units) above the measured one, within the range that was stated.
By their numbers in this assay, from the lowest: compound 1; then compounds 4, 3 and 2 (each within the scatter of the next, the first and the last beyond it).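

In this assay, among the compounds shown here, 4-methylphenyl in place of naphthalen-2-yl on this aromatic carbon gives a 1.8-fold lower number from compound 3 to compound 4 (0.25 log units; within the scatter) and is the first step that can be read at this position. At this place, a group with one six-membered aromatic ring of carbon only and a group with two such rings therefore cannot be told apart on half-life. The step is a single swap that also alters the heavy-atom count, so it cannot separate the second ring from the methyl, and no measurement bearing on the reason for the result is available.

Open, going by these compounds, is whether unsubstituted phenyl, or a phenyl carrying a carboxylic acid or a primary amine in place of the methyl, stays within the scatter of compound 4. Also open, on these data alone, is whether the same swap behaves alike on a different core.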